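Swapping a pyridine for a benzene on the piperazine arm

This account rests on a few compounds, and the source may have more. Where it says the series, first, only, none or still open, it means among the compounds named here.

Measured so far, each in a functional assay on MGC-803 cells (Homo sapiens) for antiproliferative activity, read by CCK-8 assay, with a stated time of 72 h, tested at 8 uM; a lower number here means a weaker effect, a higher number a stronger effect of the compound at the concentration tested:
- compound 1 `Nc1ccccc1NC(=O)c1ccc(CSC(=S)N2CCc3cc([N+](=O)[O-])ccc32)cc1` gives 33.2%
- compound 2 `Nc1ccccc1NC(=O)c1ccc(CSC(=S)N2CCN(Cc3ccncc3)CC2)cc1` gives 79.3%
- compound 3 `CN(Cc1ccncc1)C(=S)SCc1ccc(C(=O)Nc2ccccc2N)cc1` gives 83.2%

Among these three numbers, compound 2 stands second highest. Its nearest neighbour is compound 3, whose number is higher by an amount that lies within the usual scatter of this assay, so the two cannot be ranked against each other. Its furthest neighbour is compound 1, whose number is far lower, a gap well beyond the scatter.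

Compound 4 `Nc1ccccc1NC(=O)c1ccc(CSC(=S)N2CCN(Cc3ccccc3)CC2)cc1` has not yet been measured. It differs from compound 2 in one place: phenyl in place of pyridin-4-yl on a saturated chain carbon bound to an amine nitrogen in a ring. The (pyridin-4-yl)methyl becomes a benzyl on the same saturated chain carbon bound to an amine nitrogen in a ring.

Within the data shown here, no pair of measured compounds shows this exact change, so no measured step can guide the size of the effect. Given that compound 2 already gives 79.3%, compound 4 is expected to show a step of a number 4.3 percentage points lower from compound 2 to compound 4 (within the scatter) in this assay, a shift not beyond the scatter. Compound 4 is therefore estimated at 75%, within a range from 55% to 90%.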

Compound 4, a percentage reported as inhibition, at one concentration (the size of the read-out at that concentration, not a potency): 19.7%
The estimate for compound 4 lay 55.3 percentage points above the measured number; the whole stated range lies above it.
By their numbers in this assay, from the lowest: compound 4; then compound 1; then compounds 2 and 3 (each within the scatter of the next).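

In this assay, the aromatic ring on a saturated chain carbon bound to an amine nitrogen in a ring proves to matter greatly: phenyl in place of pyridin-4-yl gives a number 59.6 percentage points lower from compound 2 to compound 4 (beyond the scatter). Among these compounds, the two groups have the same count of heavy atoms and differ by a ring nitrogen and a hydrogen-bond acceptor, so a single atom change at this position is enough to separate a high read-out from a low one, which the earlier compounds, with no single-place step among them, could not show. No measurement available here accounts for the size of this step.

As far as these compounds go, it remains open how pyridin-3-yl or pyridin-2-yl would compare on the same carbon. Also open, from the compounds shown here alone, is whether a phenyl carrying a hydroxyl or an amino group would bring the read-out back towards that of compound 2.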